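Cyano in place of hydroxymethyl on the shared core

The source may hold more compounds than are shown below. What is called first, only, known or untested is meant among the compounds shown, and "the series" means these compounds.

In a functional assay (uterus) for inhibition, with Rattus norvegicus as the target (a lower number here means that less compound is needed, a higher number that more compound is needed for the effect), compound 1 `CCOC(=O)c1cn2cc(Br)nc(Br)c2n1` gives 0.15 nM. Compound 2 `OCc1cn2ccncc2n1` gives 2.7 nM, the higher of the two numbers, and its gap to compound 1 lies beyond the scatter. Compound 3 `N#Cc1cn2ccncc2n1` carries cyano in place of hydroxymethyl on an aromatic carbon. Within the data shown here, no measured pair isolates this change, so the expectation rests on little. No step beyond the scatter is expected in this assay, in either direction. The expected size is a 1.4-fold lower number from compound 2 to compound 3 (0.13 log units; within the scatter). Compound 3 is estimated at 2 nM, with a range of 0.3 nM to 12 nM.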

Compound 3, concentration for half-maximal effect: 2.38 nM
The estimate for compound 3 lay 1.2-fold (0.08 log units) below the measured number; the measured number falls inside the stated range.
By their numbers in this assay, from the lowest: compound 1; then compounds 3 and 2 (each within the scatter of the next).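

Among these compounds, replacing hydroxymethyl with cyano on this aromatic carbon, next to the ring nitrogen, gives the first single-place comparison: in this assay, the step (a 1.1-fold lower number from compound 2 to compound 3 (0.05 log units; within the scatter)) leaves compound 2 and compound 3 indistinguishable. At this position, therefore, the hydrogen-bond donor of hydroxymethyl is not required to keep the number within the scatter, as cyano has none. No available evidence explains this result.

As far as these compounds go, whether an aminomethyl group or a carboxylic acid at this position would also stay within the scatter remains open. The contributions of the bromines and the ester of compound 1 also remain unseparated.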